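The compounds below may be only part of what the source reports. "The series", "measured", "known", "first", "only" and "open" are said of these compounds alone.

Within the data shown here, compound 1 `[O-][S+](CCC(F)(Cl)C(F)(F)Cl)c1nc2ccccc2s1` is the only compound here with a number in a functional assay on SH-SY5Y cells (Homo sapiens) for cytotoxicity, read by MTT assay, with a stated time of 48 h (on this read-out lower numbers stand for stronger inhibition and higher numbers for weaker inhibition), where compound 1 gives 41500 nM. Compound 3 `FC(F)(Cl)C(F)(Cl)CCSc1nc2ccccc2s1` reaches only a limit of the assay, > 120000 nM. Compound 2 `FC(F)(Cl)C(F)(Cl)CCSc1nc2ccc(Cl)cc2s1` likewise reaches only a limit, > 120000 nM. Compound 2 carries chloro in place of hydrogen on an aromatic carbon, and the step that the two limits leave unreadable from compound 3 to compound 2 stays hidden because both values sit at the limit of > 120000 nM in this assay, at which 2 of the 3 values shown sit. The difference between the core of compound 1 and that of compound 3 is not broken down here. Compound 4 `[O-][S+](CCC(F)(Cl)C(F)(F)Cl)c1nc2ccc(Cl)cc2s1` is still unmeasured; it carries chloro in place of hydrogen on an aromatic carbon, the same change as from compound 3 to compound 2. The step that the two limits leave unreadable from compound 3 to compound 2 offers no readable size to lean on. The step of a 1.0-fold lower number from compound 1 to compound 4 (0.02 log units; within the scatter) is therefore expected to be small. Compound 4 is thus estimated at 40000 nM, between 15000 nM and 120000 nM.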

Compound 4, half-maximal inhibitory concentration: 2100 nM
Compound 4: the middle estimate sits 19-fold (1.28 log units) above what was measured; measured number below the stated range.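

In this assay, chloro in place of hydrogen on an aromatic carbon gives a 20-fold lower number from compound 1 to compound 4 (1.30 log units; beyond the scatter), a large and readable effect on the core of compound 1. The same change on the core of compound 3 cannot be read, because compound 3 and compound 2 both stop at a limit of the assay and not at a number: the limit of > 120000 nM in this assay, at which 2 of the 4 values shown sit. The step therefore gives a size on one core only, and it does not show whether that size carries over to the other core.

The compounds shown leave open whether another group at the same place, such as bromo, methoxy or an amine, would give a step of similar size. They also leave open how a longer chain would behave on the core of compound 4.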